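This account rests on a few compounds, and the source may have more. Where it says the series, first, only, none or still open, it means among the compounds named here.

Series notes on a set of amidines examined in a functional assay on MDA-MB-231 cells (Homo sapiens) for cytotoxicity, read by MTT assay, with a stated time of 72 h; a higher number here means a weaker inhibitor, a lower number a stronger inhibitor. Compound 3 `COc1ccc(Cn2nc(-c3ccccc3)c3cc(C(=N)Nc4ccccc4)nc(Nc4cc(OC)c(OC)c(OC)c4)c32)cc1` carries the amidine on a large, heavily substituted core, and in this assay compound 3 gives 42100 nM. Compound 1 `COc1ccc(Cn2nc(-c3ccccc3)c3cc(C(=N)Nc4cccc(C(F)(F)F)c4)nc(Nc4cc(OC)c(OC)c(OC)c4)c32)cc1` differs from compound 3 by trifluoromethyl in place of hydrogen on an aromatic carbon. For compound 1 this assay reports only a limit, > 50000 nM. The step of an at least 1.1-fold higher number from compound 3 to compound 1 (0.07 log units; that floor lies within the scatter) is thus known only as a floor, a consequence of the limit of > 50000 nM in this assay, at which 2 of the 3 values shown sit. Compound 2 `N=C(Nc1ccccc1)c1cc2cn[nH]c2cn1` holds the same amidine on a far smaller core; the difference between the two cores is not broken down here. For compound 2 this assay again reports only a limit, > 50000 nM. Compound 4 `N=C(Nc1cccc(C(F)(F)F)c1)c1cc2cn[nH]c2cn1` is compound 2 with trifluoromethyl in place of hydrogen on an aromatic carbon, the same change as that from compound 3 to compound 1, on the same kind of carbon, meta to a large group. Since that earlier step, an at least 1.1-fold higher number from compound 3 to compound 1 (0.07 log units; that floor lies within the scatter), brought no gain, the expected step is a step that the limit leaves unreadable from compound 2 to compound 4. Compound 4 is therefore estimated at 60000 nM, within 30000 nM to 150000 nM, most likely reported again as a limit.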

Compound 4, half-maximal inhibitory concentration: > 50000 nM
Compound 4 ended at the assay's limit (the forecaster's own chance of this, stated with the estimate: 85%); the middle value lies beyond the limit too.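

No new step can be read for compound 2 and compound 4, as both values are limits and the size of the change between them stays hidden: the limit of > 50000 nM in this assay, at which 3 of the 4 values shown sit.

The compounds shown leave open what trifluoromethyl in place of hydrogen on an aromatic carbon does on either core, and how far the two cores differ in this assay.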